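This account rests on a few compounds, and the source may have more. Where it says the series, first, only, none or still open, it means among the compounds named here.

In a functional assay on HL-60 cells (Homo sapiens) for antiproliferative activity, read by MTT assay, with a stated time of 48 h (on this read-out higher numbers stand for weaker inhibition and lower numbers for stronger inhibition), compound 1 (`CCN(CC)CCCn1c(N)c(-c2nc3ccccc3[nH]2)c2nc(C#N)c(C#N)nc21`) gives > 730 nM as a limit and not a number. Compound 2 (`N#Cc1nc2c(-c3nc4ccccc4[nH]3)c(N)n(CCCO)c2nc1C#N`) likewise gives > 50000 nM as a limit. Among the compounds with values here, compound 3 (`CN(C)CCCCCn1c(N)c(-c2nc3ccccc3[nH]2)c2nc(C#N)c(C#N)nc21`) gives a true number of 3420 nM and so holds the only firm value here.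

The next compound is compound 4 (`CCN(CC)CCCn1c(N)c(-c2nc3cc(Cl)ccc3[nH]2)c2nc(C#N)c(C#N)nc21`), reached from compound 1 by chloro in place of hydrogen on an aromatic carbon in the ring system; cut one bond further out, this reads 1H-benzimidazol-2-yl to 5-chloro-1H-benzimidazol-2-yl. The measured steps all change the chain instead. They are a step that the two limits leave unreadable from compound 1 to compound 2 and a step that the limit leaves unreadable from compound 1 to compound 3 and also an at least 14-fold lower number from compound 2 to compound 3 (1.16 log units; beyond the scatter) on the same chain carbon. Only the last has a readable size, and it says nothing about chloro on an aromatic carbon. Within the data shown here, no measured step touches that carbon, so the expected step in this assay is none beyond the scatter, with no firm direction.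

The expected value for compound 4 is 1200 nM with an estimated range from 350 nM to 5000 nM in repeat measurements. This estimate means a step that the limit leaves unreadable from compound 1 to compound 4 as the expected step.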

Compound 4, half-maximal inhibitory concentration: 3470 nM
Compound 4: middle estimate off by 2.9-fold (0.46 log units), on the low side; low and high end bracket the measured number.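

Compound 1 carries only a limit and not a number, so no size can be read for the change from compound 1 to compound 4. The compounds shown leave open whether chloro in place of hydrogen strengthens, weakens or leaves unchanged the inhibition.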